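This account rests on a few compounds, and the source may have more. Where it says the series, first, only, none or still open, it means among the compounds named here.

Series in a functional assay on MCF7 cells (Homo sapiens) for antiproliferative activity, read by MTT assay, with a stated time of 48 h; a higher number here means a weaker inhibitor, a lower number a stronger inhibitor:
- compound 1 `COc1ccc2c(/C=C/C(=O)c3cc(OC)c(OC)c(SC)c3)c[nH]c2c1`: 101 nM
- compound 2 `COc1ccc2c(/C=C/C(=O)c3cc(N)c(OC)c(OC)c3)c[nH]c2c1`: 249 nM
- compound 3 `COc1ccc2c(/C=C/C(=O)c3cc(N)c(OC)c(OC)c3)cn(C)c2c1`: 505 nM

Compound 3 has the highest number of the three, so it is the weakest inhibitor here. Next is compound 4 `COc1ccc2c(/C=C/C(=O)c3cc(OC)c(OC)c(SC)c3)cn(C)c2c1`, which differs from it by methylsulfanyl in place of amino on an aromatic carbon, with methylsulfanyl in place of amino on an aromatic carbon.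

Among the measured compounds shown here, two measured steps bear on this. The opposite exchange gave a 2.5-fold higher number from compound 1 to compound 2 (0.39 log units; beyond the scatter), a modest step. Methyl in place of hydrogen on an aromatic nitrogen gave a 2.0-fold higher number from compound 2 to compound 3 (0.31 log units; beyond the scatter), also modest, and compound 4 keeps that methyl. A modest move to a lower number in this assay is therefore expected, assuming the exchange carries over. The expected change is a 2.5-fold lower number from compound 3 to compound 4 (0.40 log units; beyond the scatter). For compound 4 the estimated value is 200 nM, with an expected range of 90 nM to 450 nM.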

Compound 4, half-maximal inhibitory concentration: 166 nM
For compound 4 the middle estimate is 1.2-fold (0.08 log units) above the measured one, and the stated range covers the measured number.
By their numbers in this assay, from the lowest: compounds 1, 4 and 2 (each within the scatter of the next, the first and the last beyond it); then compound 3.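

In this assay, the exchange at this position now has a second reading, on the core carrying the methyl on the aromatic nitrogen, a 3.0-fold lower number from compound 3 to compound 4 (0.48 log units; beyond the scatter), so methylsulfanyl over amino holds on both cores shown: the same change on two cores in this assay, a 2.5-fold higher number (0.39 log units; beyond the scatter) from compound 1 to compound 2 and a 3.0-fold higher number (0.48 log units; beyond the scatter) from compound 4 to compound 3, 1.2-fold (0.09 log units) apart, within the scatter of two such steps. The methyl on the aromatic nitrogen, read with methylsulfanyl in place, gives a 1.6-fold higher number from compound 1 to compound 4 (0.22 log units; within the scatter), and the two readings of that change agree: the same change on two cores in this assay, a 2.0-fold higher number (0.31 log units; beyond the scatter) from compound 2 to compound 3 and a 1.6-fold higher number (0.22 log units; within the scatter) from compound 1 to compound 4, 1.2-fold (0.09 log units) apart, within the scatter of two such steps.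

Going by these compounds, how an ethylsulfanyl or a dimethylamino group would read at this position stays open. So does a longer chain, such as ethyl, on the aromatic nitrogen.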